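The compounds below may be only part of what the source reports. "The series", "measured", "known", "first", "only" and "open" are said of these compounds alone.

In a functional assay on HEK293 cells with D(4) dopamine receptor (Homo sapiens) as the target, read by FLIPR (on this read-out lower numbers stand for smaller maximal responses and higher numbers for larger maximal responses), compound 1 `CO/N=C(\CCN1CCN(c2ccccn2)CC1)c1ccc(Cl)cc1` gives 87%. Compound 2 `CO/N=C(/CCN1CCN(c2ccccn2)CC1)c1ccc(Cl)cc1` gives 68%, and the step of a number 19 percentage points lower from compound 1 to compound 2 (beyond the scatter) rests on a single change, because of the fact that compounds 1 and 2 differ only in the configuration as drawn. Compound 3 `CO/N=C(\CCN1CCN(c2ccccn2)CC1C)c1ccc(Cl)cc1` gives 60%, the lowest of the three numbers: its gap to compound 2 lies within the scatter, while compound 1 stands beyond it. Compound 4 `CO/N=C(/CCN1CCN(c2ccccn2)CC1C)c1ccc(Cl)cc1` differs from compound 3 by the two compounds have the same atoms and bonds; at least one stereo element is drawn with a configuration in one of them and without one in the other: 1 of 2 stereo elements differ; a double bond is drawn E in compound 3 and Z in compound 4. Within the data shown here, the only measured step that bears on this change is a number 19 percentage points lower from compound 1 to compound 2 (beyond the scatter), a modest drop beyond the scatter; a similar downward step is expected here, since the methyl-bearing compound 3 already starts lower. Compound 4 is thus expected to give 45% in this assay, between 25% and 65%. The expected step is a number 15 percentage points lower from compound 3 to compound 4 (beyond the scatter).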

Compound 4, largest response reached (reported as efficacy), in percent of the reference or control that the assay uses: 45%
For compound 4 middle estimate and measured number coincide at the digits printed; the range from low to high includes it.
By their numbers in this assay, from the lowest: compound 4; then compounds 3 and 2 (each within the scatter of the next); then compound 1.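

In this assay, the switch of the double bond from E to Z now also lowers the response on the methyl-bearing core, giving a number 15 percentage points lower from compound 3 to compound 4 (beyond the scatter), in the same direction as a number 19 percentage points lower from compound 1 to compound 2 (beyond the scatter). The methyl in place of hydrogen on a saturated ring carbon also recurs with the Z double bond, giving a number 23 percentage points lower from compound 2 to compound 4 (beyond the scatter). The two methyl steps therefore agree across both double-bond configurations: the same change on two cores in this assay, a number 27 percentage points lower (beyond the scatter) from compound 1 to compound 3 and a number 23 percentage points lower (beyond the scatter) from compound 2 to compound 4, 4 percentage points apart, within the scatter of two such steps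

The compounds shown leave open whether an ethyl or a hydroxyl group on that ring carbon would lower the response as methyl does. They also leave open how the configuration at the methyl-bearing carbon bears on the number.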